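Working notes: replacing the diethylamino group of compound 3

This account rests on a few compounds, and the source may have more. Where it says the series, first, only, none or still open, it means among the compounds named here.

Values in an assay on isolated protein for inhibition of NADPH oxidase 2 (Homo sapiens), read by chemiluminescence, in the presence of a further agent that is not named here; on this read-out higher numbers stand for weaker inhibition and lower numbers for stronger inhibition:
compound 1 `CCN(CC)c1ccc(/C=C2\C(=O)N(c3ccccc3)C(=S)N2C)cc1`: 1960 nM
compound 2 `CCN(CC)c1ccc(/C=C2\C(=O)N(C3CCCCC3)C(=S)N2C)c(OC)c1`: 1950 nM
compound 3 `CCN(CC)c1ccc(/C=C2\C(=O)N(c3ccccc3)C(=S)N2C)c(OC)c1`: 1470 nM

Compound 3 gives the lowest of the three numbers, yet the steps of a 1.3-fold lower number from compound 1 to compound 3 (0.12 log units; within the scatter) and a 1.3-fold lower number from compound 2 to compound 3 (0.12 log units; within the scatter) both stay within the scatter, so no ordering among the three can be claimed. Compound 4 `COc1cc(N(C)CCCO)ccc1/C=C1\C(=O)N(c2ccccc2)C(=S)N1C` carries (3-hydroxypropyl)(methyl)amino in place of diethylamino on an aromatic carbon. Neither measured step touches this group: one concerns a methoxy group on an aromatic carbon, the other the substituent on the amide-type nitrogen in a ring, and both are small. For the measured compounds named here, there is no measured precedent for this change, and no step beyond the scatter is expected in this assay; the estimate carries the number of compound 3 forward with a wide range. Compound 4 is expected to give 1470 nM, between 500 nM and 4500 nM, a step of no change at the digits printed from compound 3 to compound 4 (within the scatter).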

Compound 4, half-maximal inhibitory concentration: 2790 nM
For compound 4 the middle estimate is 1.9-fold (0.28 log units) below the measured one; the range from low to high includes it.
By their numbers in this assay, from the lowest: compounds 3, 2, 1 and 4 (each within the scatter of the next).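

In this assay, the step to the aromatic carbon para to a large group gives a 1.9-fold higher number from compound 3 to compound 4 (0.28 log units; within the scatter), so (3-hydroxypropyl)(methyl)amino, with its added hydrogen-bond donor, can replace diethylamino here without a step beyond the scatter. This is the first change shown at this place; the earlier steps concerned only the methoxy group and the substituent on the ring nitrogen. Nothing available explains the size of this step. Still open, on these data alone, is whether a longer chain, or a carboxylic acid or an amine at the chain end, also stays within the scatter. The two changes within this swap, the shorter methyl and the hydroxypropyl chain, also remain unseparated.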